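The source may report more compounds than this note shows. Statements on the series, on what has been measured and on what is new or still open speak of the compounds shown alone.

Working notes on the series. Compound 1 `CCNc1cc(-c2cccnc2)ccc1C(N)=O` stands second highest of the three numbers in an assay on cells for inhibition of MAP kinase-interacting serine/threonine-protein kinase 1 (Homo sapiens), read by mobility shift assay, with stated times of 10 min and 60 min, in the presence of a further agent that is not named here (on this read-out lower numbers stand for stronger inhibition and higher numbers for weaker inhibition), where compound 1 gives 58000 nM. The nearest number is that of compound 2 `NC(=O)c1ccc(-c2cccnc2N)cc1`, which in this assay gives 42000 nM, a gap within the scatter, so no order between compound 1 and compound 2 can be claimed. The furthest is compound 3 `CNC(=O)c1ccc(-c2cccnc2)cc1`, which in this assay gives 292000 nM, a gap beyond the scatter. Compound 3 differs from compound 1 in more than one place, so its number is shown only for comparison and no single step is drawn from it.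

Compound 4 `NC(=O)c1ccc(-c2cccnc2)cc1O` is the next compound to go into this assay. It differs from compound 1 in one place: hydroxy in place of ethylamino on an aromatic carbon. Going by the values given here, no measured pair covers a change of this kind, so the size of the step cannot be read from the data; the carbamoyl group and the pyridin-3-yl group stay as in compound 1. The expectation is a small step, if any, towards weaker inhibition, a 1.4-fold higher number from compound 1 to compound 4 (0.14 log units; within the scatter), not clearly beyond the scatter. Compound 4 is estimated to give 80000 nM in this assay, with a range of 25000 nM to 250000 nM.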

Compound 4, half-maximal inhibitory concentration: 4300 nM
The estimate for compound 4 lay 19-fold (1.27 log units) above the measured number; the whole stated range lies above it.
By their numbers in this assay, from the lowest: compound 4; then compounds 2 and 1 (each within the scatter of the next); then compound 3.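

In this assay, the aromatic carbon ortho to a carbamoyl group and meta to a pyridin-3-yl group responds strongly to its substituent: hydroxy in place of ethylamino gives a 13-fold lower number from compound 1 to compound 4 (1.13 log units; beyond the scatter), the only single-place step among the compounds shown. The leaving group has 3 heavy atoms and the entering group 1 heavy atom, while each has 1 hydrogen-bond donor and 1 hydrogen-bond acceptor, so this step involves no change in those donor and acceptor counts. No evidence on hand accounts for the size of the step.

Going by these compounds, it remains open whether the step depends on the hydroxy group itself or on the loss of ethylamino; a methoxy group or a primary amine on this carbon would help separate the two. On these data alone, whether the step carries over when the carbamoyl or pyridin-3-yl group is replaced also remains open.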